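Benzylation of the Amino Group on the Shared Core

The source may report more compounds than this note shows. Statements on the series, on what has been measured and on what is new or still open speak of the compounds shown alone.

Three compounds of the series have numbers in an in vitro functional assay on cells for antagonist activity at transient receptor potential cation channel subfamily V member 1 (Homo sapiens), read by reporter gene assay and calcium flux; on this read-out higher numbers stand for weaker inhibition and lower numbers for stronger inhibition. Compound 1 `O=C(Nc1ccc(Cl)c(C(F)(F)F)c1)Nc1cccc2c(O)cccc12` gives 45 nM in this assay. Compound 2 `O=C(Nc1ccc(Cl)c(C(F)(F)F)c1)Nc1cccc2ccc(C(=O)O)cc12` gives 84 nM. Compound 3 `Nc1ccc2cccc(NC(=O)Nc3ccc(Cl)c(C(F)(F)F)c3)c2c1` gives 34 nM. The step from compound 2 to compound 3, amino in place of carboxy on an aromatic carbon, reads a 2.5-fold lower number from compound 2 to compound 3 (0.39 log units; beyond the scatter). Compound 3 therefore carries the lowest number of the three, though compound 1 sits within the scatter of it, so the two cannot be ordered; only compound 2 stands apart.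

Compound 4 `O=C(Nc1ccc(Cl)c(C(F)(F)F)c1)Nc1cccc2ccc(NCc3ccccc3)cc12` is the next member and is not yet measured. It differs from compound 3 by benzyl in place of hydrogen on a nitrogen on an aromatic ring, that is, amino to benzylamino. For the measured compounds named here, none of the measured steps touches this kind of change: the only recorded step swaps the group on the aromatic carbon itself and says nothing about substitution on the nitrogen of the amino group. The expectation for compound 4 therefore rests on the number of compound 3 alone, and no step beyond the scatter is expected in either direction; the expected step is a 1.3-fold higher number from compound 3 to compound 4 (0.12 log units; within the scatter). Compound 4 is estimated at 45 nM in this assay, with a range from 15 nM to 140 nM.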

Compound 4, half-maximal inhibitory concentration: 140 nM
Compound 4: middle estimate off by 3.1-fold (0.49 log units), on the low side; the range from low to high includes it.
By their numbers in this assay, from the lowest: compounds 3, 1, 2 and 4 (each within the scatter of the next, the first and the last beyond it).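

Benzyl in place of hydrogen on a nitrogen on an aromatic ring gives a 4.1-fold higher number from compound 3 to compound 4 (0.61 log units; beyond the scatter) in this assay and is the first recorded change on this nitrogen rather than on the aromatic carbon; the amino group of compound 3 therefore does not tolerate this substituent without a loss of inhibition. The advantage of amino over carboxy, a 2.5-fold lower number from compound 2 to compound 3 (0.39 log units; beyond the scatter) on the shared core, is not kept after benzylation: benzylamino in place of carboxy gives a 1.7-fold higher number from compound 2 to compound 4 (0.22 log units; within the scatter) and leaves compound 2 and compound 4 unordered. No supporting measurement on hand accounts for the step on this nitrogen, so only its size is established.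

Going by these compounds, whether the loss belongs to the benzyl group in particular or to any substituent on this nitrogen remains open, and a methyl group, an acetyl group or a longer chain ending in a phenyl ring would help to separate these readings. Also open, on these data alone, is whether a pyridine ring or a substituted phenyl ring in place of the phenyl ring of the benzyl group would recover the inhibition seen for compound 3.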